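Spiro amine in place of acetamide on the shared core

The compounds below may be only part of what the source reports. "The series", "measured", "known", "first", "only" and "open" are said of these compounds alone.

Measured compounds:
compound 1, `O=C(CCc1ccc(C(F)(F)F)cc1)Nc1ccc2nc(N3CCC(NS(=O)(=O)O)C3)ccc2c1`, 50 nM
compound 2, `CC(C)C(=O)NC1CCN(c2ccc3cc(NC(=O)CCc4ccc(C(F)(F)F)cc4)ccc3n2)C1`, 90 nM
compound 3, `CC(=O)NC1CCN(c2ccc3cc(NC(=O)CCc4ccc(C(F)(F)F)cc4)ccc3n2)C1`, 440 nM

In a functional assay on HEK293 cells for activation of melanin-concentrating hormone receptor 1 (Rattus norvegicus), read by inositol phosphate accumulation (a lower number here means that less compound is needed, a higher number that more compound is needed for the effect), compound 3 gives the highest of the three numbers; the steps of an 8.8-fold higher number from compound 1 to compound 3 (0.94 log units; beyond the scatter) and a 4.9-fold higher number from compound 2 to compound 3 (0.69 log units; beyond the scatter) both lie beyond the scatter, while a 1.8-fold higher number from compound 1 to compound 2 (0.26 log units; within the scatter) does not. Compound 4, `O=C(CCc1ccc(C(F)(F)F)cc1)Nc1ccc2nc(N3CCC4(CCNC4)C3)ccc2c1`, carries a group of 9 heavy atoms (7 carbon, 2 nitrogen; 2 five-membered non-aromatic rings with 1 hetero atom each) in place of a group of 9 heavy atoms (6 carbon, 2 nitrogen, 1 oxygen; one five-membered non-aromatic ring with 1 hetero atom), on an aromatic carbon. Among the measured compounds shown here, none of the measured steps changes the group on this aromatic carbon in the same way: the measured steps swap only the substituent on the amine nitrogen of the pyrrolidine, and each of those swaps moved the number by a modest amount. The step to compound 4 replaces the whole group, so its size is uncertain in either direction; the account therefore expects a step of roughly a 2.2-fold lower number from compound 3 to compound 4 (0.34 log units; beyond the scatter) in this assay, with a wide range. Compound 4 is estimated at 200 nM, between 40 nM and 1000 nM.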

Compound 4, half-maximal effective concentration: 140 nM
The estimate for compound 4 lay 1.4-fold (0.15 log units) above the measured number; the range from low to high includes it.
By their numbers in this assay, from the lowest: compounds 1, 2 and 4 (each within the scatter of the next, the first and the last beyond it); then compound 3.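

In this assay, among the compounds shown here, the earlier steps changed only the substituent on the amine nitrogen of the pyrrolidine, whereas here the whole 3-acetamidopyrrolidin-1-yl group on the aromatic carbon next to the ring nitrogen is replaced, and the result is a 3.1-fold lower number from compound 3 to compound 4 (0.50 log units; beyond the scatter), beyond the scatter. The entering group, with 2 five-membered non-aromatic rings and no oxygen, cannot be told apart from the isopropylcarbonyl compound, with a 1.6-fold higher number from compound 2 to compound 4 (0.19 log units; within the scatter) within the scatter, yet it stays short of the sulfo compound, with a 2.8-fold higher number from compound 1 to compound 4 (0.45 log units; beyond the scatter) beyond the scatter. No independent measurement is available to explain these steps.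

The compounds shown leave open how much the free ring amine of compound 4 contributes, as an acetyl or sulfo group on that nitrogen would test. They also leave open whether a carboxylic acid in place of the sulfo group on the pyrrolidine would give a similar number.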